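This account rests on a few compounds, and the source may have more. Where it says the series, first, only, none or still open, it means among the compounds named here.

Measured compounds:
- compound 1, `O=C(COc1c(-c2ccccc2)oc2ccccc2c1=O)Nc1ccccc1`: 6720 nM
- compound 2, `O=C(COc1c(-c2ccccc2)oc2ccccc2c1=O)Nc1ccc(F)cc1`: > 10000 nM
- compound 3, `O=C(COc1ccc2c(=O)c(-c3ccccc3)coc2c1)Nc1ccccc1`: > 10000 nM

In a functional assay on MT2 cells (Homo sapiens) for antiproliferative activity, read by MTT assay, with a stated time of 72 h (a lower number here means a stronger inhibitor of growth, a higher number a weaker inhibitor of growth), compound 1 gives 6720 nM. Compound 2 reaches only the limit of the assay, > 10000 nM, which is not a number. The change from compound 1 to compound 2 is fluoro in place of hydrogen on an aromatic carbon, and it made an at least 1.4-fold higher number from compound 1 to compound 2 (0.17 log units; that floor lies within the scatter). Compound 3 likewise sits at the limit, > 10000 nM, and that too is a limit rather than a number. Compound 1 and compound 3 share the same atoms joined differently; the difference between the two cores is not broken down here.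

Compound 4, `O=C(COc1ccc2c(=O)c(-c3ccccc3)coc2c1)Nc1ccc(F)cc1`, is not yet measured in this assay. It differs from compound 3 by fluoro in place of hydrogen on an aromatic carbon, the same change as that from compound 1 to compound 2. Two of the three values shown already sit at the limit of > 10000 nM in this assay, at which 2 of the 3 values shown sit, and the earlier step pointed to a higher number. Compound 4 is therefore expected to remain at or beyond the limit, with the step that the limit leaves unreadable from compound 3 to compound 4 standing beside the earlier one. For compound 4 the estimate is 15000 nM, from 8000 nM to 40000 nM, and the assay is expected to report only a limit.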

Compound 4, concentration for 50% growth inhibition: 2500 nM
The estimate for compound 4 lay 6.0-fold (0.78 log units) above the measured number; the whole stated range lies above it.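

In this assay the change from phenyl to 4-fluorophenyl at the anilino end gave an at least 4.0-fold lower number from compound 3 to compound 4 (0.60 log units; beyond the scatter), so on the core of compound 3 it clearly went with stronger growth inhibition. The result did not carry over from the core of compound 1, where the step on its own shows no change beyond the scatter, and the two steps differ clearly: the same change on two cores in this assay, an at least 1.4-fold higher number (0.17 log units; that floor lies within the scatter) from compound 1 to compound 2 and an at least 4.0-fold lower number (0.60 log units; beyond the scatter) from compound 3 to compound 4, at least 5.9-fold (0.77 log units) apart, beyond the scatter of two such steps This does not give the full size of either step, nor does it say why the two cores part ways, since each step is only a floor set by a value at the limit: the limit of > 10000 nM in this assay, at which 2 of the 4 values shown sit.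

On these data alone, it remains open whether chloro, methoxy or a carboxylic acid in the place of fluoro would follow compound 4 on this core, or would behave as on the core of compound 1. Also open, as far as these compounds go, is whether a longer chain joining the core to the amide would keep the gain seen with compound 4.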